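A few compounds are considered here, and "the series" means these few. Any claim that something is new, unique, unknown or untested is made for them only; others in the source may bear on it.

Measured in a functional assay (aorta) with Oryctolagus cuniculus as the target; on this read-out higher numbers stand for weaker binding and lower numbers for tighter binding:
- compound 1 `CCc1ccc(OCCCN2CCC(C(c3ccc(F)cc3)c3ccc(F)cc3)CC2)c(OC)c1`: 2.51 nM
- compound 2 `COc1cc(C(=O)O)ccc1OCCCN1CCC(C(c2ccc(F)cc2)c2ccc(F)cc2)CC1`: 79.4 nM
- compound 3 `N#Cc1ccc(OCCCN2CCC(C(c3ccc(F)cc3)c3ccc(F)cc3)CC2)cc1`: 5.01 nM

In this assay, compound 3 stands near the lower end of the numbers. Its closest comparison is a 2.0-fold higher number from compound 1 to compound 3 (0.30 log units; within the scatter), and its furthest is a 16-fold lower number from compound 2 to compound 3 (1.20 log units; beyond the scatter).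

Compound 4 `Fc1ccc(OCCCN2CCC(C(c3ccc(F)cc3)c3ccc(F)cc3)CC2)cc1` carries fluoro in place of cyano on an aromatic carbon, para to a large group (fluoro in place of cyano on an aromatic carbon). Within the data shown here, no measured step makes this swap. The large step of a 32-fold higher number from compound 1 to compound 2 (1.50 log units; beyond the scatter) brings in a carboxy group, which compound 4 lacks, so it offers little guidance. The better guide is a 2.0-fold higher number from compound 1 to compound 3 (0.30 log units; within the scatter), so no change beyond the scatter is expected. The expected step is a 1.3-fold lower number from compound 3 to compound 4 (0.10 log units; within the scatter). For compound 4 the estimated value is 4 nM, with an expected range from 1.6 nM to 10 nM.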

Compound 4, dissociation constant: 1.26 nM
Estimate against measurement, compound 4: 3.2-fold (0.50 log units) above; the measured number lies below the stated range.
By their numbers in this assay, from the lowest: compounds 4, 1 and 3 (each within the scatter of the next, the first and the last beyond it); then compound 2.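

Even without a carboxy group, this aromatic carbon responds to what it carries: in this assay, fluoro in place of cyano gives a 4.0-fold lower number from compound 3 to compound 4 (0.60 log units; beyond the scatter) on the shared core. The 4-fluorophenyl group stays level with the 4-ethyl-2-methoxyphenyl group, at a 2.0-fold lower number from compound 1 to compound 4 (0.30 log units; within the scatter), and clearly improves on the 4-carboxy-2-methoxyphenyl group, at a 63-fold lower number from compound 2 to compound 4 (1.80 log units; beyond the scatter). No measurement offered here accounts for the gain from fluoro.

Going by these compounds, whether chloro or an amine on this same carbon would behave like fluoro or like cyano stays open.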